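Shortening the acid chain on the lactam nitrogen

A few compounds are considered here, and "the series" means these few. Any claim that something is new, unique, unknown or untested is made for them only; others in the source may bear on it.

Compound 1 `O=C(O)CN1Cc2ccc(NC(=O)CCCC3CCNCC3)cc2C1=O`: 66000 nM
Compound 2 `O=C(O)CCCN1Cc2ccc(NC(=O)CC3CCNCC3)cc2C1=O`: 1800 nM

In a functional assay on a cell-free system (Platelet, plasma, Homo sapiens) for inhibition (on this read-out higher numbers stand for weaker inhibition and lower numbers for stronger inhibition), compound 2 gives 1800 nM, the lowest of the two numbers measured. Its nearest neighbour is compound 1, which in this assay gives 66000 nM, a gap that lies well beyond the scatter; compound 1 differs from compound 2 in more than one place, so no single step can be read from that pair.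

Compound 3 `O=C(O)CN1Cc2ccc(NC(=O)CC3CCNCC3)cc2C1=O` has not yet been measured. It differs from compound 2 in one place only: carboxy in place of 2-carboxyethyl on a saturated chain carbon bound to an amide-type nitrogen in a ring. The same difference, cut one bond further out, reads 3-carboxypropyl to carboxymethyl. Compound 1 already carries the carboxymethyl group and is far weaker, but it also carries a longer chain toward the piperidine, so the two pairs are not alike.

On these numbers alone, the step is expected to weaken inhibition, with a 5.6-fold higher number from compound 2 to compound 3 (0.74 log units; beyond the scatter) as the estimated size. Compound 3 is therefore expected to give about 10000 nM in this assay, within a range from 2500 nM to 40000 nM.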

Compound 3, half-maximal inhibitory concentration: 51000 nM
For compound 3 the middle estimate is 5.1-fold (0.71 log units) below the measured one; the whole stated range lies below it.
By their numbers in this assay, from the lowest: compound 2; then compounds 3 and 1 (each within the scatter of the next).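

In this assay, the acid chain on the shared core can now be judged by a single change: going from 3-carboxypropyl to carboxymethyl, on a saturated chain carbon bound to an amide-type nitrogen in a ring, gives a 28-fold higher number from compound 2 to compound 3 (1.45 log units; beyond the scatter). This shows that inhibition in this series is sensitive to the length of this acid chain, which the first two compounds could not show because they also differ in the chain toward the piperidine. With carboxymethyl in place, changing 2-(piperidin-4-yl)ethyl to piperidin-4-yl gives only a 1.3-fold lower number from compound 1 to compound 3 (0.11 log units; within the scatter), so the chain toward the piperidine makes no readable difference in this pair, and no measurement shown here explains either result.

On these data alone, it remains open whether the chain toward the piperidine is equally silent when the 3-carboxypropyl group is present, since the carboxymethyl pair may not carry over. Also unresolved is whether a longer chain such as 4-carboxybutyl would extend the gain, and whether a methyl ester could stand in for the carboxylic acid.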